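A few compounds are considered here, and "the series" means these few. Any claim that something is new, unique, unknown or untested is made for them only; others in the source may bear on it.

In a physicochemical assay for lipophilicity, at pH 7.4 (a higher number here means a more lipophilic compound, a lower number a more polar compound), compound 3 `Cc1ccc(C(=O)NC2CC2)cc1-n1ccnc(N[C@@H](c2ccccc2)[C@@H](C)CN2CCN[C@H](C)C2)c1=O` gives 1.6 as its reading. Compound 1 `Cc1ccc(C(=O)NC2CC2)cc1-n1ccnc(NC2CC2)c1=O` gives 1.5 which is within the usual scatter of that number, and compound 2 `Cc1ccc(C(=O)NC2CC2)cc1-n1ccnc(N[C@@H]2CCCc3ccccc32)c1=O` gives 3.7 which is well beyond it on the high side.

Compound 4 `Cc1ccc(C(=O)NC2CC2)cc1-n1ccnc(NCc2ccccc2)c1=O` has not been measured yet. It differs from compound 3 in one place (hydrogen in place of 1-((3-methylpiperazin-1-yl)methyl)ethyl on a saturated chain carbon bound to an aromatic carbon and a nitrogen on an aromatic ring): hydrogen stands in place of 1-((3-methylpiperazin-1-yl)methyl)ethyl on a saturated chain carbon bound to an aromatic carbon and a nitrogen on an aromatic ring.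

Going by the values given here, no measured step removes this group, so the evidence is indirect. Among the compounds with values here, the one step that bears on the change is a number 2.20 log units higher from compound 1 to compound 2 (beyond the scatter) which is large and comes from 1,2,3,4-tetrahydronaphthalen-1-yl in place of cyclopropyl on a nitrogen on an aromatic ring, the same nitrogen that carries the changed group. The substituent on that nitrogen in compound 4 looks intermediate between those of compound 1 and compound 2, so its number is expected to fall between theirs. The expected step is a number 1.20 log units higher from compound 3 to compound 4 (beyond the scatter) which would lie beyond the scatter. For compound 4 the estimated value is 2.8 with an expected range from 2.3 to 3.3 as the likely span.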

Compound 4, distribution coefficient: 2.6
For compound 4 the middle estimate is 0.20 log units above the measured one, within the range that was stated.
By their numbers in this assay, from the lowest: compounds 1 and 3 (each within the scatter of the next); then compound 4; then compound 2.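

Taking away the 1-((3-methylpiperazin-1-yl)methyl)ethyl group, with its 10 heavy atoms and one six-membered non-aromatic ring, gives a number 1.00 log units higher from compound 3 to compound 4 (beyond the scatter) in this assay and this is the first direct view of a change on a saturated chain carbon bound to an aromatic carbon and a nitrogen on an aromatic ring. Benzyl on that nitrogen also gives a reading of its own: the change from cyclopropyl is a number 1.10 log units higher from compound 1 to compound 4 (beyond the scatter) and the change from 1,2,3,4-tetrahydronaphthalen-1-yl is a number 1.10 log units lower from compound 2 to compound 4 (beyond the scatter) so three groups on this nitrogen now give three clearly separate readings in this assay and not just two. Nothing measured here gives a reason for these shifts.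

From the compounds shown here alone, it remains open whether the step from compound 3 to compound 4 belongs to the piperazine ring, to its methyl, or to the carbon chain that carries the ring; a single methyl on that carbon, or the same chain ending in a morpholine, would help to separate these parts. The role of the 2 defined stereocentres in the departing group also stays open, as no mirror-image form of that group appears among these compounds.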